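Replacing the nitrophenyl group on compound 1

This account rests on a few compounds, and the source may have more. Where it says the series, first, only, none or still open, it means among the compounds named here.

Within the data shown here, in an ADME assay on MT4 cells (Homo sapiens) for cytotoxicity, read by MTT assay (on this read-out lower numbers stand for higher toxicity in this test and higher numbers for lower toxicity in this test), compound 1 `O=C1c2ccccc2C(=O)N1CCOC(=S)N(C(=O)c1cccc([N+](=O)[O-])c1)c1ccc(Cl)cc1` gives 18000 nM as the lowest of the exact numbers so far. Compound 3 `Cc1ccc(N(C(=O)c2cccc([N+](=O)[O-])c2)C(=S)OCCN2C(=O)c3ccccc3C2=O)cc1` gives 100000 nM as the other exact number. Compound 2 `Cc1ccc(N(C(=O)c2cccc(C)c2)C(=S)OCCN2C(=O)c3ccccc3C2=O)cc1` reads > 100000 nM and that is a limit. Compound 4 `O=C1c2ccccc2C(=O)N1CCOC(=S)N(C(=O)c1ccc(F)c(F)c1)c1ccc(Cl)cc1` carries 3,4-difluorophenyl in place of 3-nitrophenyl on a carbonyl carbon and awaits measurement. Going by these compounds, the closest measured change is a number no higher from compound 2 to compound 3 (the limit leaves the size open) and it touches this same group, yet its size stays open. The other change is a 5.6-fold higher number from compound 1 to compound 3 (0.74 log units; beyond the scatter) and it concerns the chloro that compound 4 keeps, so compound 4 is expected to stay close to compound 1 in number. In this assay the estimate is a 1.4-fold higher number from compound 1 to compound 4 (0.14 log units; within the scatter) with no step beyond the scatter expected. Compound 4 is estimated at 25000 nM within an expected range from 8000 nM to 80000 nM in this test.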

Compound 4, half-maximal cytotoxic concentration: 52000 nM
Compound 4: the middle estimate sits 2.1-fold (0.32 log units) below what was measured; the measured number falls inside the stated range.
By their numbers in this assay, from the lowest: compound 1; then compounds 4 and 3 (each within the scatter of the next).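

In this assay, replacing 3-nitrophenyl with 3,4-difluorophenyl on the carbonyl carbon gives a readable change at this place: a 2.9-fold higher number from compound 1 to compound 4 (0.46 log units; beyond the scatter). Among these compounds, the earlier change at this group cannot be read, so this is the first sign that, with the chloro kept, this group alone can move the number towards lower toxicity in this test. No measurement shown gives a cause for this step.

Going by these compounds, whether an amine-bearing ring or a plain alkyl chain on this carbonyl carbon would shift the number further remains open. So does whether the same swap gives a similar step with methyl in place of the chloro.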